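The compounds below may be only part of what the source reports. "The series", "measured", "known", "first", "only" and "open" are said of these compounds alone.

Measured compounds:
compound 1, `COc1cc(Cl)cc(-c2nn(-c3cccc(NC(=O)Nc4ccc(Cl)c(C(F)(F)F)c4)c3)cc2-c2ccncc2)c1` — 2.76%
compound 2, `COc1cc(Cl)cc(-c2nn(-c3cccc(NC(=O)c4cccc(C(F)(F)F)c4)c3)cc2-c2ccncc2)c1` — 41.1%

Going by the values given here, in a functional assay on NCI-H460 cells (Homo sapiens) for inhibition, read by sulforhodamine B assay, with a stated time of 48 h, tested at 10 uM (on this read-out lower numbers stand for a stronger effect and higher numbers for a weaker effect at the one concentration tested), compound 2 stands highest of the two numbers, and the only nearby point is compound 1, since the step of a number 38.3 percentage points higher from compound 1 to compound 2 (beyond the scatter) is large and beyond the scatter. Compound 3, `COc1cc(Cl)cc(-c2nn(-c3cccc(NC(=O)c4cc(C(F)(F)F)cc(C(F)(F)F)c4)c3)cc2-c2ccncc2)c1`, differs from compound 2 by trifluoromethyl in place of hydrogen on an aromatic carbon. Among the compounds with values here, no measured step bears on this change: the one step recorded swaps the whole group on the carbonyl carbon, not a single substituent on the aromatic ring. The expected step in this assay is therefore a number 5.1 percentage points lower from compound 2 to compound 3 (within the scatter), within the scatter. Compound 3 is estimated at 36%, in the range 15% to 60%.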

Compound 3, a percentage reported as activity, at one concentration (the size of the read-out at that concentration, not a potency): 41%
For compound 3 the middle estimate is 5 percentage points below the measured one; the range from low to high includes it.
By their numbers in this assay, from the lowest: compound 1; then compounds 3 and 2 (each within the scatter of the next).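

In this assay, the step for trifluoromethyl in place of hydrogen on this aromatic carbon is a number 0.1 percentage points lower from compound 2 to compound 3 (within the scatter). Going by these compounds alone, this is the first reading of a single substituent on this ring, as the earlier step replaced the whole group on the carbonyl carbon, and here the added trifluoromethyl gives no difference beyond the scatter. Nothing available explains this result.

Going by these compounds, it remains open whether an amine or a carboxylic acid on this carbon would read differently from compound 2. On these data alone, it is also open whether the same added trifluoromethyl would leave compound 1 within the scatter.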